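Benzyl substituent swap in the aminopyrrolopyrimidine carboxamide series

The source may report more compounds than this note shows. Statements on the series, on what has been measured and on what is new or still open speak of the compounds shown alone.

Three members of the series have numbers in a functional assay on KB cells (Homo sapiens) for cytotoxicity; a higher number here means a weaker inhibitor, a lower number a stronger inhibitor. Compound 1 `C=CCn1cc(C(N)=S)c2c(N)ncnc21` gives 19000 nM in this assay. For compound 2 `COCCOCn1cc(C#N)c2c(N)ncnc21` this assay reports only a limit, > 100000 nM, and no number. Compound 3 `COc1ccc(Cn2cc(C(N)=O)c3c(N)ncnc32)cc1` gives 47000 nM in this assay, which is the highest of the two numbers available; compound 1 is nearest, with the lower number, and the gap between the two lies beyond the scatter. Among the measured compounds shown here, the amide of compound 3 has no measured partner in the set, so no step between measured compounds can be drawn.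

Compound 4 `Cc1ccc(Cn2cc(C(N)=O)c3c(N)ncnc32)cc1` has not been measured. Relative to compound 3 the change is methyl in place of methoxy on an aromatic carbon. For the measured compounds named here, no measured pair shows this change, so the expectation rests on the size of the group exchanged: a step from compound 3 to compound 4 of roughly the scatter or less, in either direction. The value of compound 4 in this assay is therefore estimated at 40000 nM, within 15000 nM to 110000 nM, which means an expected step of a 1.2-fold lower number from compound 3 to compound 4 (0.07 log units; within the scatter).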

Compound 4, half-maximal inhibitory concentration: > 100000 nM
Compound 4 gave a limit, no number; the forecaster's own chance of this, stated with the estimate: 25%; middle value at least 2.5-fold (0.39 log units) from the limit.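

Among the compounds shown here, on the aromatic carbon para to a large group, methyl in place of methoxy gives the first readable step: an at least 2.1-fold higher number from compound 3 to compound 4 (0.32 log units; beyond the scatter). In this assay compound 4 carries only a limit, > 100000 nM, so this step has a lower bound and no full size. For the compounds shown here, compounds differing in one place now show that this exchange alone moves the result beyond the scatter, with methoxy the only one of the two groups to give a number, while the limit restricts what can be read across the series: the limit of > 100000 nM in this assay, at which 2 of the 4 values shown sit.

On these data alone, whether an amine, a fluorine or a longer alkoxy chain at this place would give a number like that of compound 3 or also reach the limit stays open. Also open, as far as these compounds go, is whether the step carries over when the carboxamide gives way to the nitrile of compound 2.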